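The source may report more compounds than this note shows. Statements on the series, on what has been measured and on what is new or still open speak of the compounds shown alone.

For the measured compounds named here, compound 1 (`Cc1cn([C@H]2C[C@H](N=[N+]=[N-])[C@@H](COP(=O)(O)Oc3ccc(Br)cc3)O2)c(=O)[nH]c1=O`) and compound 2 (`O=c1ccn([C@H]2CC[C@@H](COP(=O)(O)Oc3ccncc3)O2)c(=O)[nH]1`) are the only two compounds measured so far in a physicochemical assay for metabolic stability, read by HPLC; on this read-out lower numbers stand for a shorter-lived compound and higher numbers for a longer-lived compound. Here compound 1 gives 7.97 h and holds the lower number, while compound 2 gives 23.6 h and holds the higher one, a gap beyond the usual scatter. Compound 3 (`Cc1cn([C@H]2C[C@H](N=[N+]=[N-])[C@@H](COP(=O)(O)Oc3ccncc3)O2)c(=O)[nH]c1=O`) keeps the core of compound 1 and makes one change: pyridin-4-yl in place of 4-bromophenyl on an oxygen. Going by the values given here, no measured pair shows this change alone. The nearest guide is compound 2, which carries the same pyridin-4-yl on a different core and gives 23.6 h as a loose hint only. A modest rise in this assay is expected, and the estimated step is a 1.8-fold higher number from compound 1 to compound 3 (0.24 log units; within the scatter) with wide uncertainty. For compound 3 the expected half-life is 14 h with an estimated range of 5 h to 35 h in this measurement.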

Compound 3, half-life: 8.07 h
For compound 3 the middle estimate is 1.7-fold (0.24 log units) above the measured one; measured number inside the range.
By their numbers in this assay, from the lowest: compounds 1 and 3 (each within the scatter of the next); then compound 2.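

In this assay, the swap of 4-bromophenyl for pyridin-4-yl on the oxygen bonded to phosphorus amounts to a 1.0-fold higher number from compound 1 to compound 3 (0.01 log units; within the scatter), so the two compounds cannot be told apart on this read-out. On the core of compound 1, then, this position accepts a ring with a nitrogen atom in place of a carbon-only ring carrying bromine, with no difference beyond the scatter. Nothing at hand explains why the two numbers match.

For the compounds shown here, whether this holds on the core of compound 2 remains open, since no pair shows the same change there. Also open, going by these compounds, is whether a group of another kind on the phosphorus, such as an amine or a longer alkyl chain, would give a matching half-life.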